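The compounds below may be only part of what the source reports. "The series", "measured", "known", "first", "only" and "open" are said of these compounds alone.

Measured compounds:
- Compound 1 `N#CC1=C(N)Oc2c(c3nc4ccccc4nc3c3ccccc23)C12C(=O)N(Cc1cnnn1-c1cccc(Cl)c1)c1ccccc12`: in a functional assay on HCT-116 cells (Homo sapiens) for antiproliferative activity, read by MTT assay, with a stated time of 48 h (on this read-out higher numbers stand for weaker inhibition and lower numbers for stronger inhibition), compound 1 gives > 50000 nM, which is a limit of the assay and not a number.
- Compound 2 `COc1ccc(-n2nncc2CN2C(=O)C3(C(C#N)=C(N)Oc4c3c3nc5ccccc5nc3c3ccccc43)c3ccccc32)cc1`: in this assay compound 2 gives > 50000 nM, again a limit.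
- Compound 3 `COc1ccccc1-n1nncc1CN1C(=O)C2(C(C#N)=C(N)Oc3c2c2nc4ccccc4nc2c2ccccc32)c2ccccc21`: in this assay compound 3 gives > 50000 nM, also a limit.

Compound 3 therefore stands at the limit, and the whole measured set does the same: the limit of > 50000 nM in this assay, at which 3 of the 3 values shown sit. The three steps among them, a step that the two limits leave unreadable from compound 1 to compound 2, a step that the two limits leave unreadable from compound 1 to compound 3 and a step that the two limits leave unreadable from compound 2 to compound 3, all vary the aryl group on the same aromatic nitrogen, and none of them has a readable size.

Compound 4 `Cc1cc(C)cc(-n2nncc2CN2C(=O)C3(C(C#N)=C(N)Oc4c3c3nc5ccccc5nc3c3ccccc43)c3ccccc32)c1` is the next member in this position: 3,5-dimethylphenyl in place of 2-methoxyphenyl on an aromatic nitrogen. All three measured steps bear on it, since they exchange aryl groups at the same aromatic nitrogen, yet each was left unreadable by the limit. No step beyond the scatter can be expected in this assay, and the most likely outcome is a further limit. Compound 4 is expected in this assay to give about 60000 nM, with a range from 20000 nM to 200000 nM. The expected step is therefore a step that the limit leaves unreadable from compound 3 to compound 4, meaning no change readable past the limit.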

Compound 4, half-maximal inhibitory concentration: > 50000 nM
Compound 4: only a limit was reported; the forecaster's own chance of this, stated with the estimate: 85%; the middle value is on the limit's open side.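

In this assay compound 4 gives > 50000 nM, a limit and not a number, and its steps from compound 1, compound 2 and compound 3 cannot be read. The compounds shown leave open whether any aryl group on this aromatic nitrogen gives a readable value, with the series standing at: the limit of > 50000 nM in this assay, at which 4 of the 4 values shown sit.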